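From Benzyl to 2-(Pyrrolidin-1-yl)ethyl: A Stability Question

The compounds below may be only part of what the source reports. "The series", "measured", "known", "first", "only" and "open" are said of these compounds alone.

In an in vitro ADME assay on microsomes from liver (Homo sapiens) for metabolic stability, read by LC-MS (on this read-out lower numbers stand for a shorter-lived compound and higher numbers for a longer-lived compound), compound 1 `CC(C)N1C(=O)C(=O)N=C1/N=C(\NOCc1ccccc1)Nc1ccc(Cl)c(Cl)c1` gives 0.215 h as a measured number. Compound 2 `CC(C)N1C(=O)C(=O)N=C1/N=C(\NCC(C)(C)C)Nc1ccc(Cl)c(Cl)c1` gives > 1 h and this is a limit. Compound 3 `CC(C)N1C(=O)C(=O)N=C1/N=C(\NCc1ccccc1)Nc1ccc(Cl)c(Cl)c1` gives > 1 h and this too is only a limit. The still unmeasured compound 4 `CC(C)N1C(=O)C(=O)N=C1/N=C(\NCCN1CCCC1)Nc1ccc(Cl)c(Cl)c1` differs from compound 3 at one place (pyrrolidin-1-yl)methyl in place of phenyl on a saturated chain carbon bound to an amine nitrogen with (pyrrolidin-1-yl)methyl in place of phenyl on a saturated chain carbon bound to an amine nitrogen. The step of an at least 4.6-fold higher number from compound 1 to compound 3 (0.66 log units; beyond the scatter) and the step of an at least 4.6-fold higher number from compound 1 to compound 2 (0.66 log units; beyond the scatter) both replace benzyloxy, so they bear on this change only loosely. Among the compounds with values here, only the step that the two limits leave unreadable from compound 2 to compound 3 touches the same place, and it cannot be read. A step within the scatter is therefore expected, with no direction favoured, and the estimated step is a number no higher from compound 3 to compound 4 (the limit leaves the size open) in this assay. For compound 4 the expected half-life is 1 h with an estimated range from 0.4 h to 2.5 h at this stage.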

Compound 4, half-life: 0.886 h
Compound 4: the middle estimate sits 1.1-fold (0.05 log units) above what was measured; low and high end bracket the measured number.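

Within the data shown here, with (pyrrolidin-1-yl)methyl in place of phenyl, this assay gives a measured number at this position for the first time, and the change reads as an at least 1.1-fold lower number from compound 3 to compound 4 (0.05 log units; that floor lies within the scatter). Replacing tert-butyl reads as an at least 1.1-fold lower number from compound 2 to compound 4 (0.05 log units; that floor lies within the scatter), while the basic-free comparison with benzyloxy still reads clearly as a 4.1-fold higher number from compound 1 to compound 4 (0.61 log units; beyond the scatter). The true size of the first two steps stays hidden because their starting values are limits: the limit of > 1 h in this assay, at which 2 of the 4 values shown sit.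

As far as these compounds go, how a piperidine or morpholine ring, or a longer chain leading to the pyrrolidine, would behave at this place remains open.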